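Aryl variation on the triazole of a cinnamic acid core

This account rests on a few compounds, and the source may have more. Where it says the series, first, only, none or still open, it means among the compounds named here.

The measured compounds are compound 2 `COc1ccc(/C=C\C(=O)O)c(OCc2cn(-c3ccccc3)nn2)c1CC=C(C)C` and compound 3 `COc1ccc(/C=C\C(=O)O)c(OCc2cn(-c3ccc(CO)cc3)nn2)c1CC=C(C)C`; in a functional assay on A-431 cells (Homo sapiens) for cytotoxicity, read by MTT assay, with a stated time of 24 h (on this read-out higher numbers stand for weaker inhibition and lower numbers for stronger inhibition), compound 2 gives 21200 nM and compound 3 gives 16400 nM.

Compound 1 `COc1ccc(-n2cc(COc3c(/C=C\C(=O)O)ccc(OC)c3CC=C(C)C)nn2)cc1` belongs to the same series but has no number of its own: in this assay compound 1 gives "not determined" (no result reported), so it cannot be placed against the others. Compound 4 `COc1ccc(/C=C\C(=O)O)c(OCc2cn(-c3cccc(C#N)c3)nn2)c1CC=C(C)C` differs from compound 1 in that (3-cyanophenyl in place of 4-methoxyphenyl on an aromatic nitrogen). Going by the values given here, the only step measured within this set is a 1.3-fold lower number from compound 2 to compound 3 (0.11 log units; within the scatter), a change on the same ring. Nothing measured speaks to an exchange of the entire ring substituent, so no step beyond the scatter is assumed in this assay. Compound 4 is therefore expected to give an estimated 18000 nM, with a range from 8000 nM to 40000 nM.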

Compound 4, half-maximal inhibitory concentration: 22900 nM
Estimate against measurement, compound 4: 1.3-fold (0.10 log units) below; the measured number falls inside the stated range.
By their numbers in this assay, from the lowest: compounds 3, 2 and 4 (each within the scatter of the next).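

Replacing the whole ring substituent gives a 1.4-fold higher number from compound 3 to compound 4 (0.14 log units; within the scatter) in this assay and adding cyano to the plain phenyl gives a 1.1-fold higher number from compound 2 to compound 4 (0.03 log units; within the scatter) in the same assay. Among compounds 2, 3 and 4, the aryl group on the aromatic nitrogen thus shows no step beyond the scatter, whether a hydroxymethyl or a cyano group is carried. No evidence bearing on this result is available.

From the compounds shown here alone, whether an amine or a carboxylic acid on this aryl ring would move the number beyond the scatter remains open. So does the effect of a longer alkyl chain in place of the ring.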